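Swapping a dichlorophenoxy arm for a fluorobenzylamine

A few compounds are considered here, and "the series" means these few. Any claim that something is new, unique, unknown or untested is made for them only; others in the source may bear on it.

Compound 1 `Nc1cc(N)c2nc(-c3ccccc3)c(Oc3ccc(Cl)c(Cl)c3)nc2c1` was tested in a functional assay on PC-3 cells (Homo sapiens) for inhibition, read by sulforhodamine B assay, with a stated time of 48 h; on this read-out lower numbers stand for higher toxicity in this test and higher numbers for lower toxicity in this test. In this test compound 1 reached only a limit, < 100000 nM. Compound 2 `Nc1cc(N)c2nc(-c3ccccc3)c(NCc3ccc(Cl)c(Cl)c3)nc2c1` carries a dichlorobenzylamino arm on the shared core and gives 19100 nM in this assay. For compound 3 `CCOC(=O)[C@H](CCC(=O)O)NC(=O)c1ccc(Oc2nc3cc(N)cc(N)c3nc2-c2ccccc2)cc1` the result is again a limit, < 50200 nM. For the measured compounds named here, compound 1 thus stands with the limits the limit of < 100000 nM in this assay, at which 1 of the 3 values shown sits, and (the limit of < 50200 nM in this assay, at which 1 of the 3 values shown sits), while compound 2 supplies the one measured number. Compound 4 `Nc1cc(N)c2nc(-c3ccccc3)c(NCc3ccc(F)cc3)nc2c1` has not yet been measured; it differs from compound 1 by (4-fluorobenzyl)amino in place of 3,4-dichlorophenoxy on an aromatic carbon. The step that the limit leaves unreadable from compound 1 to compound 4 is expected to lead toward the region of compound 2, which gives 19100 nM. Compound 4 is estimated at 25000 nM, with a range from 8000 nM to 80000 nM.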

Compound 4, concentration lethal to 50% of the cells: < 100000 nM
Compound 4 ended at the assay's limit; the forecaster's own chance of this, stated with the estimate: 30%; the middle value is on the limit's open side.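

In this assay, for the compounds shown here, compound 4 gives only a limit, < 100000 nM, and no step from compound 1 or compound 2 to compound 4 can be read. The compounds shown leave open where compound 1 and compound 4 actually lie.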